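Swapping Methoxy for Chloro: Expected Cytotoxicity

This account rests on a few compounds, and the source may have more. Where it says the series, first, only, none or still open, it means among the compounds named here.

Of the compounds shown here, three that share one core have been tested in an ADME assay on THP-1 cells (Homo sapiens) for cytotoxicity, read by MTT assay, with a stated time of 72 h; on this read-out lower numbers stand for higher toxicity in this test and higher numbers for lower toxicity in this test. Compound 1 `O[C@@H]1Cc2cc(OC(F)(F)F)ccc2N[C@H](c2ccccc2)C1` carries a trifluoromethoxy group, and in this assay compound 1 gives 104000 nM. Compound 2 `O[C@@H]1Cc2cc(F)ccc2N[C@H](c2ccccc2)C1` reaches only the limit of the measurement, > 300000 nM, which is not a number. The step of an at least 2.8-fold higher number from compound 1 to compound 2 (0.46 log units; beyond the scatter) points towards lower toxicity, and the limit of > 300000 nM in this assay, at which 2 of the 3 values shown sit, shows where two of the three values sit. Compound 3 `COc1cccc([C@@H]2C[C@H](O)Cc3ccccc3N2)c1` likewise stands at the limit, > 300000 nM, so its value is known only as a boundary.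

Compound 4 `O[C@@H]1Cc2ccccc2N[C@H](c2cccc(Cl)c2)C1` differs from compound 3 in one place: chloro in place of methoxy on an aromatic carbon. Among the compounds with values here, no measured step involves this change. Within the data shown here, the only measured step, an at least 2.8-fold higher number from compound 1 to compound 2 (0.46 log units; beyond the scatter), concerns a different group on a different part of the core and moved the number upwards; it offers no reason to expect compound 4 to fall clearly into the measurable range. For compound 4 a value at or near the limit is expected, 250000 nM, with a range of 80000 nM to 600000 nM. The expected step of an at least 1.2-fold lower number from compound 3 to compound 4 (0.07 log units; that floor lies within the scatter) is estimated to be none beyond the scatter.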

Compound 4, half-maximal cytotoxic concentration: 167000 nM
Beside the measured number, compound 4's estimate is 1.5-fold (0.18 log units) above it; the range from low to high includes it.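

Within the data shown here, compound 4 gives this position on the aromatic ring, meta to a large group, a reading that can be placed on the scale of this assay, something the earlier compounds with a group there did not provide. Compound 3 stands at > 300000 nM, which is a limit and not a number. Chloro in place of methoxy therefore gives an at least 1.7-fold lower number from compound 3 to compound 4 (0.25 log units; that floor lies within the scatter), so this swap is compatible with anything from no real change to a clearer move towards higher toxicity, and the true size stays hidden for the pair: the limit of > 300000 nM in this assay, at which 2 of the 4 values shown sit.

The compounds shown leave open how far the number would move with other groups at this position, such as an amine, a carboxylic acid or a longer chain, and whether any of them would bring a clear step in either direction. They also leave open whether chloro would give a similar result at another place on the same ring, and an exact number for compound 3 would be needed to fix the size of this step.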